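The source may report more compounds than this note shows. Statements on the series, on what has been measured and on what is new or still open speak of the compounds shown alone.

Compound 1, `COc1cccc(/C=C/C(=O)c2sc(Nc3cccc(Cl)c3)nc2C)c1`, gives > 25000 nM in a functional assay on NCI-H460 cells (Homo sapiens) for cytotoxicity, read by MTT assay (on this read-out lower numbers stand for stronger inhibition and higher numbers for weaker inhibition), which is a limit of the assay rather than a number.
Compound 2, `Cc1nc(Nc2cccc(Cl)c2)sc1C(=O)/C=C/c1ccccc1`, gives > 25000 nM in this assay, again a limit and not a number.

Compound 1 therefore stands at the limit of this assay, with no number of its own; (the limit of > 25000 nM in this assay, at which 2 of the 2 values shown sit), so nothing within the measured set gives it a place other than that limit. The unmeasured compound 3, `COc1cccc(/C=C/C(=O)c2sc(Nc3ccc(C)cc3)nc2C)c1`, differs from compound 1 in one place: 4-methylphenyl in place of 3-chlorophenyl on a nitrogen on an aromatic ring. For the measured compounds named here, the only measured step, a step that the two limits leave unreadable from compound 1 to compound 2, concerns the methoxy group and not the ring on the nitrogen, and it cannot be read in size. Going by the values given here, no measured step bears on the change from compound 1 to compound 3, and no direction can be taken from the data. For compound 3 the step that the limit leaves unreadable from compound 1 to compound 3 is therefore expected to be unreadable as well, with the likely outcome being another limit. The estimate for compound 3 in this assay is 40000 nM, in a range from 12000 nM to 120000 nM, and it is expected that the assay will most probably report only a limit for compound 3.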

Compound 3, half-maximal inhibitory concentration: > 25000 nM
Compound 3: no number, only a limit (the forecaster's own chance of this, stated with the estimate: 80%); the middle value is on the limit's open side.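

Compound 3, like compound 1, gives only a limit in this assay, so the change between compound 1 and compound 3 cannot be read as a step. The compounds shown leave open whether 4-methylphenyl in place of 3-chlorophenyl makes any difference, as all of them stand at one value that is not a number: the limit of > 25000 nM in this assay, at which 3 of the 3 values shown sit.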